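Working Notes: From Compound 1 to Compound 4

The compounds below may be only part of what the source reports. "The series", "measured", "known", "first", "only" and "open" are said of these compounds alone.

Compound 1 `CCCN(CCC)S(=O)(=O)c1ccc(S(=O)(=O)N2CCC[C@@H](C(=O)OCC)C2)cc1` is the reference point of these notes. In a functional assay on MIA PaCa-2 cells (Homo sapiens) for inhibition, read by MTT assay, with a stated time of 3 days (a lower number here means a stronger inhibitor, a higher number a weaker inhibitor), compound 1 returns only the limit of the measurement, > 10000 nM, so no number is known for it. Compound 2 `CCN(CC)C(=O)[C@@H]1CCCN(S(=O)(=O)c2ccc(S(=O)(=O)N(CC)CC)cc2)C1` also sits at the limit in this assay, giving > 10000 nM. Compound 3 `CCOC(=O)[C@@H]1CCCN(S(=O)(=O)c2ccc(S(=O)(=O)N(CC)CC)nc2)C1` likewise returns only a limit in this assay, > 10000 nM. All three values therefore coincide with the limit of > 10000 nM in this assay, at which 3 of the 3 values shown sit, and no ranking among compound 1, compound 2 and compound 3 can be drawn from them.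

Compound 4 `CCOC(=O)[C@@H]1CCCN(S(=O)(=O)c2ccc(C(=O)N(CC)CC)cc2)C1` has not yet been measured in this assay. It differs from compound 1 in one place: diethylcarbamoyl in place of dipropylsulfamoyl on an aromatic carbon. No measured pair in this set carries a comparable exchange, so the size of the effect cannot be read from any shown step. With every shown value at the limit, the step from compound 1 to compound 4 is expected to be a step that the limit leaves unreadable from compound 1 to compound 4, with no direction beyond the scatter that the data could support. It is expected that compound 4 will most likely again return only a limit. The estimate for compound 4 in this assay is 15000 nM, in a range from 5000 nM to 50000 nM.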

Compound 4, half-maximal inhibitory concentration: > 10000 nM
Compound 4: no number, only a limit; the forecaster's own chance of this, stated with the estimate: 80%; the middle value does not contradict the limit.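

Compound 4 gives > 10000 nM in this assay, which is a limit and not a number. Compound 1 also returns only a limit, so no step can be read between compound 1 and compound 4. The compounds shown leave open how they rank and which change to the shared core would give a readable number, with all values at one mark: the limit of > 10000 nM in this assay, at which 4 of the 4 values shown sit.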